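Cytotoxicity notes on compound 2 and compound 4

The source may report more compounds than this note shows. Statements on the series, on what has been measured and on what is new or still open speak of the compounds shown alone.

The series is read in an ADME assay on cells (Homo sapiens) for cytotoxicity, read by resazurin assay, with a stated time of 5 days; on this read-out lower numbers stand for higher toxicity in this test and higher numbers for lower toxicity in this test. Compound 1 `COc1ccc(-c2nc(C(C)S(=O)(=O)c3cccc(Cl)c3)nc3ccsc23)cn1` reports only a limit in this assay, > 50000 nM, and not a number. Compound 3 `O=S(=O)(Cc1nc(-c2ccoc2)c2sccc2n1)c1cccc(Cl)c1` likewise sits at a limit in this assay, > 50000 nM. Compound 2 `COc1ccc(-c2nc(CSc3cc(C)cc(C)c3)nc3ccsc23)cn1` stands at the same point: in this assay compound 2 gives > 50000 nM, which is a limit of the test rather than a measured value. Going by the values given here, all three values so far rest on (the limit of > 50000 nM in this assay, at which 3 of the 3 values shown sit), so nothing within the measured group separates one compound from another, and no step between measured compounds can be drawn.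

Compound 4 `COc1ccc(-c2nc(CSc3cccc(Cl)c3)nc3ccsc23)cn1` has not yet been measured. It differs from compound 2 in one place: 3-chlorophenyl in place of 3,5-dimethylphenyl on a sulfur. Among the compounds with values here, no measured step describes such a change. Within the data shown here, with every value so far sitting at the limit of > 50000 nM in this assay, at which 3 of the 3 values shown sit, compound 4 is expected to return a limit as well. The change is therefore estimated as none beyond the scatter, a number no higher from compound 2 to compound 4 (the limit leaves the size open). For compound 4 the estimate in this assay is 50000 nM, with a range from 20000 nM to 50000 nM, and the most likely outcome is that the assay again reports only the limit.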

Compound 4, half-maximal cytotoxic concentration: > 10000 nM
Compound 4: no number, only a limit (the forecaster's own chance of this, stated with the estimate: 85%); the middle value does not contradict the limit.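

In this assay compound 4 gives > 10000 nM, which is a limit and not a number. Going by these compounds alone, compound 2 gives > 50000 nM, also a limit, so no step between compound 2 and compound 4 can be read. The compounds shown leave open at what concentration, if any, cytotoxicity would appear in this assay.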